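The source may report more compounds than this note shows. Statements on the series, on what has been measured and on what is new or still open speak of the compounds shown alone.

The measured compounds:
compound 1, `COc1cccc(NC(=O)c2nnn(Cc3ccc(SC)cc3)c2N)c1`; in a physicochemical assay for solubility, read by nephelometry, at pH 7.4 (a higher number here means a more soluble compound, a lower number a less soluble compound), compound 1 gives < 12000 nM, which is a limit of the assay rather than a number.
compound 2, `COc1cccc(NC(=O)c2nnn(Cc3ccc(C4CC4)cc3)c2N)c1`; in this assay compound 2 gives 79000 nM.

Among the compounds with values here, compound 2 therefore stands as the only number in this assay; the other value shown is a limit. Within the data shown here, the single measured step is an at least 6.5-fold higher number from compound 1 to compound 2 (0.81 log units; beyond the scatter), a change on an aromatic carbon. Compound 3, `COc1cccc(NC(=O)c2nnn(Cc3ccc([S+](C)[O-])cc3)c2N)c1`, is the next compound, and it differs from compound 2 in this way: a group of 3 heavy atoms (1 carbon, 1 oxygen, 1 sulfur; no ring) in place of a group of 3 heavy atoms (3 carbon; one three-membered non-aromatic ring of carbon only), on an aromatic carbon. The change sits on the same aromatic carbon, so the step of an at least 6.5-fold higher number from compound 1 to compound 2 (0.81 log units; beyond the scatter) is the only one that bears on it, and it was at least modest. The evidence is thin: it consists of the limit of < 12000 nM in this assay, at which 1 of the 2 values shown sits, which tells how far the earlier value reached but not where it lies. Among the measured compounds shown here, with only that step to lean on, compound 3 is expected to stay at a measurable number, with an expected step of a 1.3-fold lower number from compound 2 to compound 3 (0.12 log units; within the scatter) that does not exceed the scatter. The estimate for compound 3 is 60000 nM, with a range from 15000 nM to 240000 nM.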

Compound 3, solubility: > 250000 nM
Compound 3: only a limit was reported (the forecaster's own chance of this, stated with the estimate: 15%); middle value at least 4.1-fold (0.61 log units) away from the limit.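

In this assay compound 3 gives > 250000 nM as a limit of the assay and not a number. Until now the position on an aromatic carbon, para to a large group, had shown only that cyclopropyl stood clear of methylsulfanyl, but the step to the new group, which has no ring and carries 1 hydrogen-bond acceptor against 0 for cyclopropyl, is an at least 3.1-fold higher number from compound 2 to compound 3 (0.50 log units; beyond the scatter) and shows that cyclopropyl does not mark the top of the range at this position. Set against methylsulfanyl, the same group gives an at least 20-fold higher number from compound 1 to compound 3 (1.31 log units; beyond the scatter) and places the two sulfur-bearing groups at opposite ends of the three compounds, so sulfur at this position does not by itself fix the read-out in either direction.

Where compound 3 lies beyond its limit remains open, and with it the true size of both steps. Going by these compounds, it also remains open whether the rise extends to a methylsulfonyl group, with a second oxygen on the sulfur, or to groups without sulfur, such as a carboxylic acid or a morpholine, at the same position.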